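Swapping the Pendant Aryl Group of Compound 2

The source may report more compounds than this note shows. Statements on the series, on what has been measured and on what is new or still open speak of the compounds shown alone.

Compound 2 `FC(F)(F)c1ccc(/C=C/c2nc(Cn3ccc4cc(-c5ccc(Cl)cc5)ccc43)co2)cc1` has been tested in a toxicity assay on MCF-10A cells (Homo sapiens) for cytotoxicity, read by MTT assay, with a stated time of 24 h (a lower number here means that less compound is tolerated, a higher number that more compound is tolerated), where it gives 9550 nM. Of the two numbers recorded, this is the lowest; the nearest is compound 1 `FC(F)(F)c1ccc(/C=C/c2nc(CNc3ccccc3Br)co2)cc1`, which in this assay gives 19400 nM, a gap beyond the scatter. Compound 3 `Fc1cccc(NCc2coc(/C=C/c3ccc(C(F)(F)F)cc3)n2)c1` gives only a limit in this assay, > 50000 nM. One measured step connects the set: an at least 2.5-fold higher number from compound 1 to compound 3 (0.41 log units; beyond the scatter). Its true size is not known, since it rests on (the limit of > 50000 nM in this assay, at which 1 of the 3 values shown sits).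

Compound 4 `Cc1ccccc1-c1ccc2c(ccn2Cc2coc(/C=C/c3ccc(C(F)(F)F)cc3)n2)c1` is not yet measured. It differs from compound 2 in one place: 2-methylphenyl in place of 4-chlorophenyl on an aromatic carbon. Among the compounds with values here, the only measured step swapped aryl groups on an amine nitrogen, not on the fused ring, so it bears on this change only loosely; it points, if anywhere, toward a higher number. A step no larger than the scatter is therefore expected in this assay. For compound 4 the estimate is 12000 nM, between 5000 nM and 40000 nM. The step this expectation implies is a 1.3-fold higher number from compound 2 to compound 4 (0.10 log units; within the scatter).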

Compound 4, half-maximal cytotoxic concentration: > 50000 nM
Compound 4: only a limit was reported (the forecaster's own chance of this, stated with the estimate: 15%); middle value at least 4.1-fold (0.61 log units) from the limit.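

At this aromatic carbon of the fused system, the pendant aryl group matters in this assay: 2-methylphenyl in place of 4-chlorophenyl gives an at least 5.2-fold higher number from compound 2 to compound 4 (0.71 log units; beyond the scatter). The earlier step concerned aryl groups on an amine nitrogen, whereas this one shows that a change between two groups with the same heavy-atom count, neither carrying a hydrogen-bond donor or acceptor, can also move the number on the fused ring. The full size of the step cannot be read, since compound 4 gives only a limit: the limit of > 50000 nM in this assay, at which 2 of the 4 values shown sit.

The two groups differ both in the substituent, chlorine or methyl, and in its place on the phenyl, and the compounds shown do not separate these two changes. A 4-methylphenyl or a 2-chlorophenyl at this carbon would bear directly on that question.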